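Chloro to Fluoro on the Aryl Ring of Compound 1

The source may report more compounds than this note shows. Statements on the series, on what has been measured and on what is new or still open speak of the compounds shown alone.

Measured so far:
Compound 1 `CC(c1ccc(-c2ccccc2)c(F)c1)c1nnc2n1N=C(c1ccc(Cl)cc1)CS2` gives 3800 nM
Compound 2 `CC(c1ccc(-c2ccccc2)c(F)c1)c1nnc2n1N=C(c1ccc(Cl)cc1Cl)CS2` gives 4700 nM
Compound 3 `CC(c1ccc(-c2ccccc2)c(F)c1)c1n[nH]c(=S)n1N` gives "not active" (no number reported)

In a functional assay on SNU-475 cells (Homo sapiens) for inhibition, read by sulforhodamine B assay, with a stated time of 72 h (on this read-out lower numbers stand for stronger inhibition and higher numbers for weaker inhibition), compound 1 has the lowest of the two numbers reported, and compound 2 sits closest to it: the step of a 1.2-fold higher number from compound 1 to compound 2 (0.09 log units; within the scatter) is within the scatter, so the two cannot be told apart. Compound 3, which lacks the fused part of the shared core, is reported only as not active in this assay, with no number.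

Compound 4 `CC(c1ccc(-c2ccccc2)c(F)c1)c1nnc2n1N=C(c1ccc(F)cc1)CS2` has not yet been measured. It differs from compound 1 in one place: fluoro in place of chloro on an aromatic carbon. The same spot is where compound 2 carries its added chloro, and that step, the only measured one bearing on this position, was within the scatter. Among the compounds with values here, nothing measured shows how a fluoro behaves here, so the expectation for compound 4 rests on the small size of the one neighbouring step. A number for compound 4 near that of compound 1, with at most a modest rise, is expected: a 1.3-fold higher number from compound 1 to compound 4 (0.12 log units; within the scatter). For compound 4 the estimate in this assay is 5000 nM, within a range from 2000 nM to 12000 nM.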

Compound 4, half-maximal inhibitory concentration: 6600 nM
Beside the measured number, compound 4's estimate is 1.3-fold (0.12 log units) below it; the measured number falls inside the stated range.
By their numbers in this assay, from the lowest: compounds 1, 2 and 4 (each within the scatter of the next).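

In this assay, fluoro in place of chloro on this aromatic carbon gives a 1.7-fold higher number from compound 1 to compound 4 (0.24 log units; within the scatter), so this exchange of one halogen for another, the first tested at this spot, produces no difference that can be told apart from ordinary repeat variation. Measured against the compound with two chloro groups, 4-fluorophenyl in place of 2,4-dichlorophenyl gives a 1.4-fold higher number from compound 2 to compound 4 (0.15 log units; within the scatter), so that larger change in the ring's substitution cannot be resolved either, and compound 1, compound 2 and compound 4 all read alike within the scatter. With three halogen patterns on this ring reading alike, the position has so far shown no clear response to which halogen it carries or to a second chloro, and no supporting measurement is available to explain this.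

All three of these compounds carry only halogens on this ring, so it remains open whether a methoxy group, an amine or a carboxylic acid at the same spot would give a number clearly apart from theirs. On these data alone, it also remains open how the plain phenyl ring, with hydrogen at this spot, would compare with them.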